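Trimming the alkylamino chain: isobutyl to ethyl

The compounds below may be only part of what the source reports. "The series", "measured", "known", "first", "only" and "open" are said of these compounds alone.

Compound 1 `CCCNc1nnc(SCC(=O)N(Cc2cccc([N+](=O)[O-])c2)c2ccc(F)cc2)s1` gives 20.5% in an assay on isolated protein for inhibition of Amine oxidase [flavin-containing] A (Homo sapiens), read by fluorescence and Amplex Red, with a stated time of 30 min, tested at 1 nM; a higher number here means a stronger effect of the compound at the concentration tested, a lower number a weaker effect.
Compound 2 `CC(C)CNc1nnc(SCC(=O)N(Cc2cccc([N+](=O)[O-])c2)c2ccc(F)cc2)s1` gives 17.3% in this assay.
Compound 3 `C=CCNc1nnc(SCC(=O)N(Cc2cccc([N+](=O)[O-])c2)c2ccc(F)cc2)s1` gives 20.5% in this assay.

Compound 2 has the lowest of the three numbers, but its gaps to compound 1 and to compound 3 are both within the scatter, so no order among them can be claimed. Compound 4 `CCNc1nnc(SCC(=O)N(Cc2cccc([N+](=O)[O-])c2)c2ccc(F)cc2)s1` differs from compound 2 by methyl in place of isopropyl on a saturated chain carbon bound to a nitrogen on an aromatic ring. Among the compounds with values here, the steps that bear on this are a number 3.2 percentage points lower from compound 1 to compound 2 (within the scatter) and a number 3.2 percentage points higher from compound 2 to compound 3 (within the scatter), both small changes at the same place and both within the scatter. A further shortening of the chain is therefore expected to leave this assay essentially unchanged: the step of a number 1.7 percentage points higher from compound 2 to compound 4 (within the scatter) is the estimate. Compound 4 is expected to give about 19%, in the range 10% to 28%.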

Compound 4, a percentage reported as inhibition, at one concentration (the size of the read-out at that concentration, not a potency): 21%
Estimate against measurement, compound 4: 2 percentage points below; low and high end bracket the measured number.
By their numbers in this assay, from the lowest: compounds 2, 1, 3 and 4 (each within the scatter of the next).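

Shortening the chain to ethyl gives no readable difference in this assay: the steps are a number 3.7 percentage points higher from compound 2 to compound 4 (within the scatter), a number 0.5 percentage points higher from compound 3 to compound 4 (within the scatter) and a number 0.5 percentage points higher from compound 1 to compound 4 (within the scatter). The shortest chain among these compounds therefore joins the other three with no order among them, so across these four compounds the chain shows no readable effect on the number at this place. Nothing available bears on why the read-out stays level here.

Open, from the compounds shown here alone, is whether an unsubstituted amino group, a phenyl ring or a much longer chain such as octyl at this place would separate from these four compounds.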